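The source may hold more compounds than are shown below. What is called first, only, known or untested is meant among the compounds shown, and "the series" means these compounds.

Measured compounds:
compound 1 `COc1ccc(C(=O)c2cc(OC)c(OC)c(OC)c2)c(NC(=O)CO)c1` — 120 nM
compound 2 `COc1ccc(C(=O)c2cc(OC)c(OC)c(OC)c2)c(NC(=O)CN(C)C)c1` — 790 nM
compound 3 `C=C(c1cc(OC)c(OC)c(OC)c1)c1ccc(OC)c(O)c1NC(=O)CN(C)C` — 110 nM

All three numbers come from a functional assay on HCT-8 cells (Homo sapiens) for antiproliferative activity, read by MTT assay, with a stated time of 48 h; on this read-out higher numbers stand for weaker inhibition and lower numbers for stronger inhibition. Compound 1 and compound 2 share one core and differ in a single place: hydroxy in place of dimethylamino on a saturated chain carbon bound to a carbonyl carbon. That change gives a 6.6-fold lower number from compound 2 to compound 1 (0.82 log units; beyond the scatter). Compound 3 carries a different core; the difference between the core of compound 3 and the core of compound 2 is not broken down here. In this assay compound 3 gives 110 nM, and compound 1 gives 120 nM; the gap between them is within the scatter, so no order is read between these two. Against compound 2, compound 3 sits beyond the scatter.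

Compound 4 `C=C(c1cc(OC)c(OC)c(OC)c1)c1ccc(OC)c(O)c1NC(=O)CO` is not yet measured. It stands to compound 3 as compound 1 stands to compound 2: hydroxy in place of dimethylamino on a saturated chain carbon bound to a carbonyl carbon. The place is the same in both pairs, so this is the same kind of change carried onto the other core. Going by the values given here, the only guide for its size is a 6.6-fold lower number from compound 2 to compound 1 (0.82 log units; beyond the scatter); whether the second core carries the change the same way is unknown, as these two pairs are the only ones at hand. The expected step in this assay is a 3.7-fold lower number from compound 3 to compound 4 (0.56 log units; beyond the scatter), set smaller than the earlier one because the guide a 6.6-fold lower number from compound 2 to compound 1 (0.82 log units; beyond the scatter) rests on a single pair on another core. Compound 4 is expected to give 30 nM in this assay, with a range from 8 nM to 120 nM.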

Compound 4, half-maximal inhibitory concentration: 40 nM
Compound 4: middle estimate off by 1.3-fold (0.12 log units), on the low side; the measured number falls inside the stated range.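

In this assay, hydroxy in place of dimethylamino on a saturated chain carbon bound to a carbonyl carbon gives a 2.8-fold lower number from compound 3 to compound 4 (0.44 log units; beyond the scatter), so the step seen on the first core recurs on the second in the same direction. Set side by side, the two steps cannot be told apart in size: the same change on two cores in this assay, a 6.6-fold lower number (0.82 log units; beyond the scatter) from compound 2 to compound 1 and a 2.8-fold lower number (0.44 log units; beyond the scatter) from compound 3 to compound 4, 2.4-fold (0.38 log units) apart, within the scatter of two such steps. Going by these compounds alone, this supports carrying the change between these two cores as a lowering of the number, but with only two pairs in one cell assay it does not establish a rule for other cores or other read-outs, and it does not show why the number falls.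

Only hydroxy and dimethylamino are shown at this place, which leaves open how a primary amine, a methoxy group, a carboxylic acid or a longer chain ending in hydroxy would read on either core. Also open, as far as these compounds go, is which part of the difference between the two cores bears on the number, as that difference is not broken down into single changes here.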